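The source may report more compounds than this note shows. Statements on the series, on what has been measured and on what is new or still open speak of the compounds shown alone.

In an ADME assay on CCRF-HSB-2 cells (Homo sapiens) for cytotoxicity, with a stated time of 7 days (on this read-out lower numbers stand for higher toxicity in this test and higher numbers for lower toxicity in this test), compound 3 `CCCCCCSc1nc(N)nc2c1ncn2/C=C1/CC1(CO)CO` gives 60000 nM and is the only one of the three measured compounds with a true number. Compound 1 `Nc1nc(OCC(F)(F)F)c2ncn(/C=C3/CC3(CO)CO)c2n1` shows > 20000 nM as a limit of the assay, not a number. Compound 2 `CCCCCCCCOc1nc(N)nc2c1ncn2/C=C1/CC1(CO)CO` shows > 20000 nM as a limit too. The unmeasured compound 4 `CCCCCOc1nc(N)nc2c1ncn2/C=C1/CC1(CO)CO` carries pentyloxy in place of hexylsulfanyl on an aromatic carbon, a change counted as pentyloxy in place of hexylsulfanyl on an aromatic carbon when set against compound 3. For the measured compounds named here, three measured steps bear on this change, namely a step that the limit leaves unreadable from compound 2 to compound 3 and a step that the limit leaves unreadable from compound 1 to compound 3 and a step that the two limits leave unreadable from compound 1 to compound 2 but none of them has a readable size. Thus the limit of > 20000 nM in this assay, at which 2 of the 3 values shown sit, is the only guide. No change beyond the usual scatter is expected, in either direction. The expected step is a 1.2-fold lower number from compound 3 to compound 4 (0.08 log units; within the scatter) and it remains only an estimate. The estimate for compound 4 is 50000 nM within an expected range of 20000 nM to 120000 nM in this test.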

Compound 4, half-maximal cytotoxic concentration: > 20000 nM
Compound 4: only a limit was reported; the forecaster's own chance of this, stated with the estimate: 60%; the middle value does not contradict the limit.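

For the compounds shown here, compound 4 shows only a limit, so no new step to compound 4 from compound 1, compound 2 or compound 3 can be read in this assay. The compounds shown leave open whether pentyloxy and hexylsulfanyl differ at all in this assay.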